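This account rests on a few compounds, and the source may have more. Where it says the series, first, only, none or still open, it means among the compounds named here.

Measured so far:
- Compound 1 `Fc1ccccc1NCn1nc(-c2ccc3c(c2)OCCO3)oc1=S` gives 6390 nM
- Compound 2 `Fc1cccc(F)c1NCn1nc(-c2ccc3c(c2)OCCO3)oc1=S` gives 3320 nM
- Compound 3 `FC(F)(F)c1cccc(NCn2nc(-c3ccc4c(c3)OCCO4)oc2=S)c1` gives 7620 nM

In a functional assay, with a stated time of 6 min (a lower number here means a stronger inhibitor, a higher number a weaker inhibitor), compound 3 (7620 nM) cannot be told apart from compound 1 (6390 nM) within the scatter, while compound 2 (3320 nM) gives a lower number than compound 3, a gap beyond the scatter. Compound 4 `S=c1oc(-c2ccc3c(c2)OCCO3)nn1CNc1cccc(Cl)c1` has not been measured yet. It differs from compound 3 by chloro in place of trifluoromethyl on an aromatic carbon. Among the compounds with values here, no measured step makes this exchange. Within the data shown here, the only measured step (a 1.9-fold lower number from compound 1 to compound 2 (0.28 log units; within the scatter)) puts fluoro in place of hydrogen and stays within the scatter, so it offers only a weak guide. The expected change in this assay is small (a 1.3-fold lower number from compound 3 to compound 4 (0.10 log units; within the scatter)) and no larger than the scatter. For compound 4 the estimated value is 6000 nM (expected range 3000 nM to 12000 nM).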

Compound 4, half-maximal inhibitory concentration: 6220 nM
Estimate against measurement, compound 4: 1.0-fold (0.02 log units) below, and the stated range covers the measured number.
By their numbers in this assay, from the lowest: compounds 2, 4, 1 and 3 (each within the scatter of the next, the first and the last beyond it).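

In this assay, chloro in place of trifluoromethyl on this aromatic carbon gives a small step (a 1.2-fold lower number from compound 3 to compound 4 (0.09 log units; within the scatter)), so one chlorine atom serves here as well as the four heavy atoms of trifluoromethyl. The wider swaps to 3-chlorophenyl on the amine nitrogen (a 1.9-fold higher number from compound 2 to compound 4 (0.27 log units; within the scatter); a 1.0-fold lower number from compound 1 to compound 4 (0.01 log units; within the scatter)) also stay small, so compound 4 cannot be told apart from compound 1 or compound 2. No available evidence explains this flat result.

Still open, going by these compounds, is whether an amine or a carboxylic acid on this ring would move the number beyond the scatter.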